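One Side Chain Exchanged on a Shared Core

A few compounds are considered here, and "the series" means these few. Any claim that something is new, unique, unknown or untested is made for them only; others in the source may bear on it.

In a functional assay on MGC-803 cells (Homo sapiens) for cytotoxicity, read by MTT assay, with a stated time of 38 h (on this read-out lower numbers stand for stronger inhibition and higher numbers for weaker inhibition), compound 1 `COc1cc(OC)c2c(=O)c(OCC(=O)N/N=C/c3sccc3C)c(-c3cc(OC)c(OC)c(OC)c3)oc2c1` gives 7740 nM, and compound 2 `COc1cc(OC)c2c(=O)c(OCCCCN3CCN(C)CC3)c(-c3cc(OC)c(OC)c(OC)c3)oc2c1` gives 12200 nM. Among the measured compounds shown here, these are the only two numbers so far, and compound 2 stands within the scatter of compound 1. Compound 3 `COc1cc(OC)c2c(=O)c(OCC(=O)N/N=C/c3ccccn3)c(-c3cc(OC)c(OC)c(OC)c3)oc2c1` has not yet been measured. It differs from compound 2 at a single place, where the 3-(4-methylpiperazin-1-yl)propyl group leaves: a group of 11 heavy atoms (7 carbon, 3 nitrogen, 1 oxygen; one six-membered aromatic ring with 1 hetero atom) in place of a group of 10 heavy atoms (8 carbon, 2 nitrogen; one six-membered non-aromatic ring with 2 hetero atoms), on a saturated chain carbon bound to an oxygen on an aromatic ring. For the measured compounds named here, the one measured step that bears on this is a 1.6-fold higher number from compound 1 to compound 2 (0.20 log units; within the scatter). That step exchanged a comparable pair of groups in the opposite sense, although the group in compound 1 holds a five-membered aromatic ring and the entering group a six-membered one. Going by the values given here, no measured compound shows what that difference between the rings does. Among the compounds with values here, with the only available step inside the scatter, just a small shift is expected in this assay, toward a lower number but not beyond the scatter: an estimated 1.6-fold lower number from compound 2 to compound 3 (0.21 log units; within the scatter). Compound 3 is expected at about 7500 nM, with an estimated range of 2500 nM to 20000 nM.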

Compound 3, half-maximal inhibitory concentration: 15300 nM
For compound 3 the middle estimate is 2.0-fold (0.31 log units) below the measured one, and the stated range covers the measured number.
By their numbers in this assay, from the lowest: compounds 1, 2 and 3 (each within the scatter of the next).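

In this assay, the second exchange of a whole group on the saturated chain carbon bound to an oxygen on an aromatic ring gives a 1.3-fold higher number from compound 2 to compound 3 (0.10 log units; within the scatter) and, like the first, does not separate the two compounds. New here is a 2.0-fold higher number from compound 1 to compound 3 (0.30 log units; within the scatter) as the first step that keeps the rest of the side chain and exchanges only its end, pyridin-2-yl in place of 3-methylthiophen-2-yl on a carbon with a double bond to nitrogen, and this smaller exchange also stays within the scatter. Nothing at hand offers an explanation for what these three compounds show.

On these data alone, the last step changes the ring and removes the methyl group together, so a comparison with an unsubstituted thiophen-2-yl group, which would separate those two changes, remains open. Also open, as far as these compounds go, is whether any other group at this place, such as a primary amine or a carboxylic acid on a shorter or longer chain, would carry the number beyond the scatter of these three compounds.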